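The source may hold more compounds than are shown below. What is called first, only, known or untested is meant among the compounds shown, and "the series" means these compounds.

Compound 2 `Cc1cnn(-c2cnoc2N)c1` and compound 1 `Nc1oncc1-n1cccn1` share one core. In an assay on SW48 cells for inhibition of Tryptophan 2,3-dioxygenase (Homo sapiens), read by fluorescence, with a stated time of 30 min (a lower number here means that less compound is needed, a higher number that more compound is needed for the effect), compound 1 gives 230 nM and compound 2 gives 340 nM; the two numbers lie within the scatter of each other, as the step of a 1.5-fold higher number from compound 1 to compound 2 (0.17 log units; within the scatter) shows. Compound 3 `Nc1oncc1-n1cc(F)cn1` differs from compound 2 by fluoro in place of methyl on an aromatic carbon. Among the compounds with values here, the only measured step touching this carbon, the methyl step, stayed within the scatter, so in this assay no step beyond the scatter is expected in either direction. For compound 3 the estimate is therefore 300 nM, expected between 120 nM and 800 nM, a step of a 1.1-fold lower number from compound 2 to compound 3 (0.05 log units; within the scatter).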

Compound 3, half-maximal effective concentration: 77 nM
Compound 3: the middle estimate sits 3.9-fold (0.59 log units) above what was measured; measured number outside the range, below it.
By their numbers in this assay, from the lowest: compound 3; then compounds 1 and 2 (each within the scatter of the next).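

This carbon is not indifferent to its group in this assay: hydrogen and methyl there lie within the scatter of each other, yet fluoro gives a 4.4-fold lower number from compound 2 to compound 3 (0.64 log units; beyond the scatter) and a 3.0-fold lower number from compound 1 to compound 3 (0.48 log units; beyond the scatter). The methyl step alone could not show that a change at this carbon can move the number beyond the scatter. Nothing given here explains why fluoro stands apart. On these data alone, whether the lower number belongs to fluoro alone stays open, and chloro, nitrile or methoxy on this carbon would test that. As far as these compounds go, how far the step carries over to other positions on the shared core also remains open.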